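Chloro in place of methyl on compound 2

The source may hold more compounds than are shown below. What is called first, only, known or untested is meant among the compounds shown, and "the series" means these compounds.

In a functional assay on MDA-MB-231 cells (Homo sapiens) for inhibition, read by MTT assay, with a stated time of 72 h (on this read-out lower numbers stand for stronger inhibition and higher numbers for weaker inhibition), compound 1 `COc1ccc(-c2cc(C(=O)N3CCC4(CC3)CC(=O)c3nn(C(C)(C)C)cc3O4)c3ccccc3n2)cc1` gives > 10000 nM, which is a limit and not a number. Going by the values given here, compound 2 `Cc1cc(C(=O)N2CCC3(CC2)CC(=O)c2nn(C(C)(C)C)cc2O3)c2ccccc2n1` gives 4860 nM, the only true number so far. Among the compounds with values here, the one measured step, an at least 2.0-fold lower number from compound 1 to compound 2 (0.31 log units; beyond the scatter), puts methyl in place of 4-methoxyphenyl, and its exact size stays unknown because of the limit of > 10000 nM in this assay, at which 1 of the 2 values shown sits. Compound 3 `CC(C)(C)n1cc2c(n1)C(=O)CC1(CCN(C(=O)c3cc(Cl)nc4ccccc34)CC1)O2` differs from compound 2 by a smaller swap, (chloro in place of methyl on an aromatic carbon), with chloro in place of methyl on an aromatic carbon. That step offers only a loose guide, so the expected change, a 1.1-fold lower number from compound 2 to compound 3 (0.03 log units; within the scatter), stays within the scatter. Compound 3 is estimated at 4500 nM, with an expected range of 1800 nM to 10000 nM.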

Compound 3, half-maximal inhibitory concentration: 9220 nM
Compound 3: middle estimate off by 2.0-fold (0.31 log units), on the low side; low and high end bracket the measured number.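

In this assay, chloro in place of methyl on this aromatic carbon next to the ring nitrogen gives a 1.9-fold higher number from compound 2 to compound 3 (0.28 log units; within the scatter) and the two cannot be told apart. Exchanging these two single heavy atoms therefore gives no change beyond the usual scatter, which the earlier pair, with its much larger swap, could not show. Compound 1 gives a limit and not a number. Chloro in place of 4-methoxyphenyl gives an at least 1.0-fold lower number from compound 1 to compound 3 (0.03 log units; that floor lies within the scatter) and the exact size of that step stays unknown: the limit of > 10000 nM in this assay, at which 1 of the 3 values shown sits.

Going by these compounds, whether an amine, a hydroxyl or a nitrile at this position would shift the number beyond the scatter remains open.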